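Adding a methoxy to the phenyl of compound 2

The source may hold more compounds than are shown below. What is called first, only, known or untested is meant among the compounds shown, and "the series" means these compounds.

Measured so far:
compound 1 `O=C(/C=C/c1cccc(O)c1)c1cccc(-n2cc(-c3ccccc3)[nH]c2=O)c1` — 3860 nM in a functional assay on MDA-MB-231 cells (Homo sapiens) for inhibition; on this read-out higher numbers stand for weaker inhibition of growth and lower numbers for stronger inhibition of growth
compound 2 `COc1cc(/C=C/C(=O)c2cccc(-n3cc(-c4ccccc4)[nH]c3=O)c2)cc(OC)c1OC` — 2170 nM in this assay

Compound 2 has the lowest of the two numbers in this assay, but its gap to compound 1 lies within the scatter, so the two cannot be ranked. Compound 3 `COc1ccc(-c2cn(-c3cccc(C(=O)/C=C/c4cc(OC)c(OC)c(OC)c4)c3)c(=O)[nH]2)cc1` differs from compound 2 by methoxy in place of hydrogen on an aromatic carbon. Going by the values given here, no pair of measured compounds shows what such a change does here, so in this assay no step beyond the scatter is expected. Compound 3 is therefore estimated at 1800 nM, with a range from 700 nM to 5000 nM. That estimate amounts to an expected step of a 1.2-fold lower number from compound 2 to compound 3 (0.08 log units; within the scatter).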

Compound 3, concentration for 50% growth inhibition: 5480 nM
Beside the measured number, compound 3's estimate is 3.0-fold (0.48 log units) below it; the whole stated range lies below it.
By their numbers in this assay, from the lowest: compounds 2, 1 and 3 (each within the scatter of the next, the first and the last beyond it).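

Phenyl to 4-methoxyphenyl gives the only step so far that clears the scatter: in this assay the number rises, a 2.5-fold higher number from compound 2 to compound 3 (0.40 log units; beyond the scatter), which means weaker inhibition of growth. So this position on the ring is not indifferent to what it carries, and methoxy there does not help. Nothing measured here explains why the number rises.

As far as these compounds go, whether fluorine or an amine in that place would move the number the same way stays open. So does whether methoxy would give a similar step on compound 1.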